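A Pyridazinyl Ether in Place of the Phenyl Ether

This account rests on a few compounds, and the source may have more. Where it says the series, first, only, none or still open, it means among the compounds named here.

Compound 1, `CC(C)(C)OC(=O)N1CCC(O[C@H]2CC[C@@H](Oc3ccc(S(C)(=O)=O)cc3)CC2)CC1`: 266 nM
Compound 2, `CC(C)(C)OC(=O)N1CCC(O[C@H]2CC[C@H](Oc3ccc(S(C)(=O)=O)cc3)CC2)CC1`: 16.1 nM
Compound 3, `CC(C)(C)OC(=O)N1CCC(O[C@H]2CC[C@H](Oc3ccc(S(C)(=O)=O)cc3F)CC2)CC1`: 8.5 nM

In a functional assay on isolated protein for agonist activity at Glucose-dependent insulinotropic receptor (Homo sapiens), read by HTRF and cAMP accumulation (on this read-out lower numbers stand for an effect already at smaller amounts and higher numbers for an effect only at larger amounts of compound), compound 2 stands second highest of the three numbers. Compound 3 is nearest, with a 1.9-fold lower number from compound 2 to compound 3 (0.28 log units; within the scatter), and compound 1 furthest, with a 17-fold lower number from compound 1 to compound 2 (1.22 log units; beyond the scatter), a step that rests on (the fact that compounds 1 and 2 differ only in the configuration as drawn). Compound 4, `CC(C)(C)OC(=O)N1CCC(O[C@H]2CC[C@H](Oc3ccc(S(C)(=O)=O)nn3)CC2)CC1`, differs from compound 2 in one place: 6-(methylsulfonyl)pyridazin-3-yl in place of 4-(methylsulfonyl)phenyl on an oxygen on a saturated carbon. Among the measured compounds shown here, no measured step exchanges the aromatic ring itself; the one step that alters the ring, adding fluoro, stays within the scatter, and the large step concerns configuration alone. For the measured compounds named here, for this ring exchange there is thus no direct precedent, and only a modest step, if any, is expected in this assay. Compound 4 is estimated at 30 nM (range 8 nM to 120 nM), which means a 1.9-fold higher number from compound 2 to compound 4 (0.27 log units; within the scatter).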

Compound 4, half-maximal effective concentration: 651 nM
The estimate for compound 4 lay 22-fold (1.34 log units) below the measured number; measured number above the stated range.
By their numbers in this assay, from the lowest: compounds 3 and 2 (each within the scatter of the next); then compound 1; then compound 4.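

In this assay, among the compounds shown here, the exchange of 4-(methylsulfonyl)phenyl for 6-(methylsulfonyl)pyridazin-3-yl gives a 40-fold higher number from compound 2 to compound 4 (1.61 log units; beyond the scatter), whereas the only earlier change on this ring, fluoro in place of hydrogen, gave a 1.9-fold lower number from compound 2 to compound 3 (0.28 log units; within the scatter). The position on the oxygen thus responds strongly to the identity of the aromatic ring, and not only to the configuration of the shared core. Nothing measured here accounts for this step. The compounds shown leave open whether a pyridine ring carrying the same methylsulfonyl group would stay close to compound 2 or fall nearer compound 4.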